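Cyano in place of the side group of compound 2

A few compounds are considered here, and "the series" means these few. Any claim that something is new, unique, unknown or untested is made for them only; others in the source may bear on it.

In a functional assay (aorta) for inhibition, with Rattus norvegicus as the target (a lower number here means a stronger inhibitor, a higher number a weaker inhibitor), compound 1 `CC(C)/N=C(\S)[C@]1(c2cccnc2)CCCC[S+]1[O-]` reads 10000 nM as a measured number. Compound 2 `N/N=C(\S)[C@]1(c2cccnc2)CCCC[S+]1[O-]` reads > 30000 nM and that is a limit of the assay, not a number. For the measured compounds named here, the one measured step on this group is an at least 3.0-fold higher number from compound 1 to compound 2 (0.47 log units; beyond the scatter) and it runs toward weaker inhibition. Compound 3 `N#C[C@]1(c2cccnc2)CCCC[S+]1[O-]` carries cyano instead, on a saturated ring carbon, with a group of 2 heavy atoms (1 carbon, 1 nitrogen; no ring) in place of a group of 4 heavy atoms (1 carbon, 2 nitrogen, 1 sulfur; no ring), on a saturated ring carbon as the count. Going by the values given here, with compound 2 at its limit and only the step of an at least 3.0-fold higher number from compound 1 to compound 2 (0.47 log units; beyond the scatter) as a guide, no recovery is expected in this assay here. The expected step is a number no higher from compound 2 to compound 3 (the limit leaves the size open) and no more. Compound 3 is estimated at 30000 nM within 10000 nM to 100000 nM and may well read only as a limit.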

Compound 3, concentration for 90% inhibition: > 30000 nM
Compound 3 gave a limit, no number (the forecaster's own chance of this, stated with the estimate: 70%); the middle value sits exactly at the limit.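

Cyano, with no hydrogen-bond donors, does not lift activity on the saturated ring carbon in this assay: compound 3 reads > 30000 nM, which is a limit and not a number. For the compounds shown here, the change to cyano gives an at least 3.0-fold higher number from compound 1 to compound 3 (0.47 log units; beyond the scatter), so amino is not the only replacement that leaves compound 1 behind. The step between compound 2 and compound 3 cannot be read, both values being limits: the limit of > 30000 nM in this assay, at which 2 of the 3 values shown sit.

Open, as far as these compounds go, is whether a longer chain in place of isopropyl on the double-bonded nitrogen would improve on compound 1, and whether a carboxylic acid on the saturated ring carbon would give a number at all.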